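Series notes: dimethylamino in place of cyano

The compounds below may be only part of what the source reports. "The series", "measured", "known", "first", "only" and "open" are said of these compounds alone.

Measured in a physicochemical assay for solubility, using the shake flask method, in simulated intestinal fluid, measured as kinetic solubility, with a stated time of 2 h, at 25 degrees C, at pH 6.5; on this read-out higher numbers stand for higher solubility and lower numbers for lower solubility:
- compound 1 `Cc1noc(-c2nc(C)c3c(c2N)C(=O)N(Cc2cccc(F)c2)C3=O)n1`: < 5000 nM
- compound 2 `Cc1noc(-c2nc(C)c3c(c2N)C(=O)N(Cc2ccc(OC(F)F)cc2)C3=O)n1`: < 5000 nM
- compound 3 `Cc1noc(-c2nc(C)c3c(c2N)C(=O)N(Cc2ccc(C#N)cc2)C3=O)n1`: < 5000 nM

The measured compounds share one reading, (the limit of < 5000 nM in this assay, at which 3 of the 3 values shown sit). Compound 3 has no number in this assay, and its < 5000 nM is a limit of the assay. The two other compounds are limits as well, so the three cannot be ranked.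

The next compound is compound 4 `Cc1noc(-c2nc(C)c3c(c2N)C(=O)N(Cc2ccc(N(C)C)cc2)C3=O)n1`. The change is dimethylamino in place of cyano on an aromatic carbon, para to a large group.

The nearest measured change is a step that the two limits leave unreadable from compound 2 to compound 3, which also swaps the group at this place. The other two are a step that the two limits leave unreadable from compound 1 to compound 2 and a step that the two limits leave unreadable from compound 1 to compound 3. None of these steps has a readable size, so none of them gives a direction for the new change.

No step beyond the scatter can therefore be expected in this assay on these data, and a further limit is the likeliest report. What is expected is a step that the limit leaves unreadable from compound 3 to compound 4, with no direction supported. For compound 4 the estimated value is 3000 nM, with an expected range from 800 nM to 8000 nM.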

Compound 4, solubility: 7400 nM
Estimate against measurement, compound 4: 2.5-fold (0.39 log units) below; the measured number falls inside the stated range.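

In this assay, for the compounds shown here, compound 4 is the first compound with a substituent at this place, on an aromatic carbon para to a large group, to give a number rather than a limit: 7400 nM. Dimethylamino in place of cyano reads as an at least 1.4-fold higher number from compound 3 to compound 4 (0.17 log units; that floor lies within the scatter), dimethylamino in place of difluoromethoxy as an at least 1.4-fold higher number from compound 2 to compound 4 (0.17 log units; that floor lies within the scatter), and 4-(dimethylamino)phenyl in place of 3-fluorophenyl as an at least 1.4-fold higher number from compound 1 to compound 4 (0.17 log units; that floor lies within the scatter). All three are floors and none is shown to exceed the scatter, while the steps among compound 1, compound 2 and compound 3 cannot be read, and those three compounds stay unranked: the limit of < 5000 nM in this assay, at which 3 of the 4 values shown sit.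

On these data alone, the true size of each step to compound 4 stays open, since only the floors can be read. Also open, as far as these compounds go, is whether a number in this assay is particular to dimethylamino, or would also appear with a primary amine, a morpholine ring or a carboxylic acid at the same place.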